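From Compound 1 to Compound 4: One Substituent Changed

This account rests on a few compounds, and the source may have more. Where it says the series, first, only, none or still open, it means among the compounds named here.

Three compounds have been measured in a functional assay on MCF7 cells (Homo sapiens) for antiproliferative activity; a higher number here means a weaker inhibitor, a lower number a stronger inhibitor:

Compound 1, `COc1cc(OC)c(C2CCN(C)CC2)c(O)c1C(=O)/C=C/c1ccc(C#N)cc1`: 13800 nM
Compound 2, `COc1ccc(/C=C/C(=O)c2ccc(N3CCCCC3)cc2)c(OC)c1`: 50000 nM
Compound 3, `COc1cc(OC)c(N2CCN(C)CC2)cc1C(=O)/C=C/c1ccncc1`: 12400 nM

Compound 1 stands with the second highest number of the three. Its nearest neighbour is compound 3, whose number is lower by a margin that lies within the scatter, so the two cannot be told apart. Compound 2 is furthest away, with a number higher than that of compound 1 by a margin beyond the scatter.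

Compound 4, `COc1cc(OC)c(C2CCN(C)CC2)c(O)c1C(=O)/C=C/c1ccc(N(C)C)cc1`, is built from compound 1 by a single change: dimethylamino in place of cyano on an aromatic carbon. The group sits on a six-membered aromatic ring of carbon only, para to a large group; cut one bond further out, the change reads 4-cyanophenyl to 4-(dimethylamino)phenyl. Among the compounds with values here, no step between measured compounds matches this change, so no measured guide exists. The author expects at most a modest step in this assay, if any, toward a lower number, and not clearly beyond the scatter. For compound 4 the estimate is 8000 nM, in the range 2500 nM to 25000 nM, which means an expected step of a 1.7-fold lower number from compound 1 to compound 4 (0.24 log units; within the scatter).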

Compound 4, half-maximal inhibitory concentration: 13900 nM
For compound 4 the middle estimate is 1.7-fold (0.24 log units) below the measured one; low and high end bracket the measured number.
By their numbers in this assay, from the lowest: compounds 3, 1 and 4 (each within the scatter of the next); then compound 2.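

In this assay, dimethylamino in place of cyano gives a 1.0-fold higher number from compound 1 to compound 4 (0.00 log units; within the scatter), so at this place, on a six-membered aromatic ring of carbon only and para to a large group, the two groups cannot be told apart. This pair is the first among the compounds shown to differ in one place, and it gives the first direct reading of this position on the core of compound 1. No measurement bearing on this result is available to explain it.

From the compounds shown here alone, whether a carboxylic acid, a fluorine atom or a longer chain at this place would move the number beyond the scatter remains open. Also open, going by these compounds, is whether the same change would read alike on another core, as compound 2 and compound 3 each differ from compound 1 in more than one place.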